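Carbamate to Trifluoromethyl Benzoate on a Weakly Active Core

A few compounds are considered here, and "the series" means these few. Any claim that something is new, unique, unknown or untested is made for them only; others in the source may bear on it.

The account begins with compound 1 `CC1=CC[C@H]2[C@@H]1CC=C(C)[C@@H](CC[C@H]1[C@]3(C)CC[C@H](O)C(C)(C)O[C@H]3CC[C@@]1(C)O)C2(C)C`, a free alcohol at the position later acylated. In a functional assay on MDA-MB-231 cells (Homo sapiens) for antiproliferative activity, read by MTT assay, with a stated time of 72 h (on this read-out lower numbers stand for stronger inhibition and higher numbers for weaker inhibition), compound 1 reaches only a limit of the assay, > 50000 nM. That limit is recorded as the limit of > 50000 nM in this assay, at which 1 of the 2 values shown sits. Compound 2 `CC1=CC[C@H]2[C@H](CC[C@]2(C)O)C(C)(C)[C@@H]1CC[C@H]1[C@]2(C)CC[C@H](OC(=O)NCc3ccccc3)C(C)(C)O[C@H]2CC[C@@]1(C)O` carries a benzyl carbamate at that alcohol, and in this assay compound 2 gives 40300 nM. Among the numbers shown, compound 2 stands as the only measured value; the other entry is a limit rather than a number, so no measured step between two numbers exists here.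

Compound 3 `CC1=CC[C@H]2[C@H](CC[C@]2(C)O)C(C)(C)[C@@H]1CC[C@H]1[C@]2(C)CC[C@H](OC(=O)c3ccccc3C(F)(F)F)C(C)(C)O[C@H]2CC[C@@]1(C)O` is the next member, and it differs from compound 2 by a single change: 2-(trifluoromethyl)phenyl in place of benzylamino on a carbonyl carbon. Within the data shown here, no step between measured compounds is available to calibrate this exchange, so the expectation rests on compound 2 alone. Given that compound 2 gives 40300 nM, the step of a 1.2-fold lower number from compound 2 to compound 3 (0.06 log units; within the scatter) is expected to stay within the usual scatter of this assay, with no direction favoured. Compound 3 is therefore estimated at 35000 nM, with a range from 12000 nM to 60000 nM.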

Compound 3, half-maximal inhibitory concentration: 31500 nM
The estimate for compound 3 lay 1.1-fold (0.05 log units) above the measured number; low and high end bracket the measured number.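

Among these compounds, at this position the step is the first that can be read between two measured numbers. In this assay, placing 2-(trifluoromethyl)phenyl where benzylamino stood on the carbonyl carbon gives a 1.3-fold lower number from compound 2 to compound 3 (0.11 log units; within the scatter), so the two compounds cannot be told apart. The carbamate and the benzoate ester therefore read alike here, even though the amide hydrogen and the linking nitrogen are gone, which shows that in this one pair neither is needed to hold the value where it stands. Compound 1, with its free alcohol, remains a limit and not a number, and its core also differs, so no step to it can be read: the limit of > 50000 nM in this assay, at which 1 of the 3 values shown sits.

As far as these compounds go, it remains open whether the trifluoromethyl group contributes anything to compound 3, since a plain phenyl ring or a methoxy group in its place would be needed to tell. From the compounds shown here alone, it is equally open whether an acyl group carrying an amine or a carboxylic acid, or a longer alkyl chain on the carbonyl carbon, would give a number clearly apart from those of compound 2 and compound 3.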